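Benzothiazole amides: dimethyl in place of methoxy

This account rests on a few compounds, and the source may have more. Where it says the series, first, only, none or still open, it means among the compounds named here.

Measured compounds:
compound 1 `O=C(Nc1nc2ccc(Cl)cc2s1)c1cc(-c2ccc(F)cc2)n2nc(-c3ccccc3)cc2n1` gives 19800 nM
compound 2 `COc1ccc2nc(NC(=O)c3cc(-c4ccc(F)cc4)n4nc(-c5ccccc5)cc4n3)sc2c1` gives 24500 nM

In a functional assay on MCF7 cells (Homo sapiens) for cytotoxicity, read by MTT assay, with a stated time of 48 h (a higher number here means a weaker inhibitor, a lower number a stronger inhibitor), compound 1 gives 19800 nM and compound 2 gives 24500 nM. Compound 2 stands within the scatter of compound 1, as a 1.2-fold higher number from compound 1 to compound 2 (0.09 log units; within the scatter) shows. Compound 3 `Cc1cc2nc(NC(=O)c3cc(-c4ccc(F)cc4)n4nc(-c5ccccc5)cc4n3)sc2cc1C` carries 5,6-dimethyl-1,3-benzothiazol-2-yl in place of 6-methoxy-1,3-benzothiazol-2-yl on an amide-type nitrogen. Going by the values given here, the only measured step that bears on it is a 1.2-fold higher number from compound 1 to compound 2 (0.09 log units; within the scatter), which is within the scatter; no step beyond the scatter is therefore expected in this assay. Compound 3 is estimated at 23000 nM, with a range from 9000 nM to 60000 nM. The expected step is a 1.1-fold lower number from compound 2 to compound 3 (0.03 log units; within the scatter), within the scatter.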

Compound 3, half-maximal inhibitory concentration: 17000 nM
The estimate for compound 3 lay 1.4-fold (0.13 log units) above the measured number; the range from low to high includes it.
By their numbers in this assay, from the lowest: compounds 3, 1 and 2 (each within the scatter of the next).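

In this assay, 5,6-dimethyl-1,3-benzothiazol-2-yl on the amide-type nitrogen stays within the scatter of both earlier groups, with a 1.4-fold lower number from compound 2 to compound 3 (0.16 log units; within the scatter) and a 1.2-fold lower number from compound 1 to compound 3 (0.07 log units; within the scatter). Two methyl groups on the ring therefore separate no better from 6-methoxy-1,3-benzothiazol-2-yl or 6-chloro-1,3-benzothiazol-2-yl than those two did from each other. No supporting data bear on this result. On these data alone, whether a 1,3-benzothiazol-2-yl carrying an amine or a carboxylic acid would give a step beyond the scatter remains open. As far as these compounds go, the compounds also share the rest of the core, so changes there remain untested in these notes.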